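Capping the hydroxy group of compound 2

The source may report more compounds than this note shows. Statements on the series, on what has been measured and on what is new or still open speak of the compounds shown alone.

Measured in a functional assay on NCI/ADR-RES cells (Homo sapiens) for inhibition, read by sulforhodamine B assay, with a stated time of 48 h; on this read-out lower numbers stand for stronger inhibition of growth and higher numbers for weaker inhibition of growth:
compound 1 `CC1(/C=C/c2ccccc2)C=CC(=O)O1`: 414000 nM
compound 2 `CC1(/C=C/c2cccc(O)c2)C=CC(=O)O1`: 647000 nM

For the measured compounds named here, compound 2 stands within the scatter of compound 1, the only other compound measured. Compound 3 `COc1cccc(/C=C/C2(C)C=CC(=O)O2)c1` differs from compound 2 by methyl in place of hydrogen on an oxygen on an aromatic ring. Going by the values given here, no measured step makes this exact change. Among the compounds with values here, the one related step, hydroxy in place of hydrogen on an aromatic carbon, is a 1.6-fold higher number from compound 1 to compound 2 (0.19 log units; within the scatter), so no change beyond the scatter is expected in this assay. The expected step is a 1.2-fold lower number from compound 2 to compound 3 (0.07 log units; within the scatter). The estimate for compound 3 is 550000 nM, with an expected range from 300000 nM to 1000000 nM.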

Compound 3, concentration for total growth inhibition: 48600 nM
Compound 3: the middle estimate sits 11-fold (1.05 log units) above what was measured, outside the stated range (below it).
By their numbers in this assay, from the lowest: compound 3; then compounds 1 and 2 (each within the scatter of the next).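

Methyl on the oxygen on the aromatic ring does what the free hydroxy did not in this assay: hydroxy to methoxy gives (a 13-fold lower number from compound 2 to compound 3 (1.12 log units; beyond the scatter)). The methoxy compound also stands apart from the compound without a substituent on that ring (an 8.5-fold lower number from compound 1 to compound 3 (0.93 log units; beyond the scatter)), so among these three only methoxy brings stronger inhibition of growth. Nothing offered here accounts for this.

Whether the effect is particular to methyl remains open, since a longer chain such as ethoxy on that oxygen, or an amine in place of the methoxy, is not among the compounds shown.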